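The source may report more compounds than this note shows. Statements on the series, on what has been measured and on what is new or still open speak of the compounds shown alone.

Working notes on the series.

Three compounds share the core of compound 1 `COC(=O)N1C(=O)NC(C)=C(C(=O)OC(C)C)C1c1cccc([N+](=O)[O-])c1` and have numbers in an assay on HEK293 cells for antagonist activity at Voltage-dependent L-type calcium channel subunit alpha-1D (Rattus norvegicus), read by FLIPR; a higher number here means a weaker inhibitor, a lower number a stronger inhibitor. Compound 1 gives 2960 nM. For the measured compounds named here, compound 2 `CC1=C(C(=O)OC(C)C)C(c2cccc([N+](=O)[O-])c2)N(C(=O)C(C)C)C(=O)N1` gives 990 nM, and the step of a 3.0-fold lower number from compound 1 to compound 2 (0.48 log units; beyond the scatter) is the only single-point comparison measured so far. Compound 3 `COC(=O)C1=C(C)NC(=O)N(C(=O)OC(C)C)C1c1cccc([N+](=O)[O-])c1` gives 4600 nM, the highest of the three numbers; its gap to compound 1 lies within the scatter, its gap to compound 2 lies beyond it.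

Compound 4 `CC1=C(C(=O)OC(C)C)C(c2cccc([N+](=O)[O-])c2)N(C(=O)OC(C)C)C(=O)N1` is not yet measured. It differs from compound 3 by isopropyl in place of methyl on an oxygen next to a carbonyl group. Going by the values given here, no measured step touches this position: the step from compound 1 to compound 2 changed a substituent on a carbonyl carbon, not on an oxygen, and it was modest in size. Compounds 1 and 3, which carry methyl and isopropyl in swapped places, sit within the scatter of each other, so the present data give no firm signal for this exchange.

Compound 4 is therefore expected to land close to compound 3, with at most a small shift toward lower numbers, a 1.8-fold lower number from compound 3 to compound 4 (0.26 log units; within the scatter). The estimate for compound 4 in this assay is 2500 nM, with a range from 700 nM to 9000 nM.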

Compound 4, half-maximal inhibitory concentration: 660 nM
The estimate for compound 4 lay 3.8-fold (0.58 log units) above the measured number, and the stated range ends above it.
By their numbers in this assay, from the lowest: compounds 4 and 2 (each within the scatter of the next); then compounds 1 and 3 (each within the scatter of the next).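

In this assay, isopropyl in place of methyl on an oxygen next to a carbonyl group now gives a clear shift toward lower numbers, seen from two starting points (a 7.0-fold lower number from compound 3 to compound 4 (0.84 log units; beyond the scatter)) and (a 4.5-fold lower number from compound 1 to compound 4 (0.65 log units; beyond the scatter)). Compound 1 and compound 3 could not be told apart, yet each has one methoxycarbonyl, and methoxycarbonyl to isopropoxycarbonyl gives a change beyond the scatter from either of them, so the exchange carries a real signal that the earlier numbers did not show. Isopropoxy in place of isopropyl on a carbonyl carbon separates nothing (a 1.5-fold lower number from compound 2 to compound 4 (0.18 log units; within the scatter)), and no measurement at hand explains any of these shifts.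

The compounds shown carry only methyl and isopropyl on this oxygen, so it remains open whether ethyl, tert-butyl or a longer chain would extend the shift or reverse it. Also open, on these data alone, are how an amine on the carbonyl carbon would compare with isopropoxy and isopropyl, and where a compound with two methoxycarbonyl groups would fall.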